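The compounds below may be only part of what the source reports. "The series", "measured", "known", "first", "only" and "open" are said of these compounds alone.

Among the compounds with values here, compound 3 `COc1ccc(/C=C/c2cc(OC)cc(OC)c2/C=C/C(=O)c2ccc(Cl)c(Cl)c2)cc1` gives 7.5 ug/mL in a functional assay on B16-F10 cells (Mus musculus) for antiproliferative activity, read by MTT assay, with a stated time of 48 h (on this read-out lower numbers stand for stronger inhibition and higher numbers for weaker inhibition), the highest of the three numbers so far; compound 1 `CCCCOc1ccc(C(=O)/C=C/c2c(/C=C/c3ccc(OC)cc3)cc(OC)cc2OC)cc1` stands nearest with 5.3 ug/mL, and compound 2 `COc1ccc(/C=C/c2cc(OC)cc(OC)c2/C=C/C(=O)c2ccccc2)cc1` stands furthest with 3.7 ug/mL. Compound 4 `COc1ccc(/C=C/c2cc(OC)cc(OC)c2/C=C/C(=O)c2ccc(N)cc2)cc1` differs from compound 3 by 4-aminophenyl in place of 3,4-dichlorophenyl on a carbonyl carbon. The measured steps that bear on this change both alter the ring on the carbonyl carbon: a 2.0-fold higher number from compound 2 to compound 3 (0.31 log units; beyond the scatter) and a 1.4-fold higher number from compound 1 to compound 3 (0.15 log units; within the scatter). Neither moved the number far, so exchanging this ring has so far produced only small shifts in this assay. For compound 4 the expected step is a 1.5-fold lower number from compound 3 to compound 4 (0.18 log units; within the scatter), either within the scatter or a modest lowering of the number. Compound 4 is therefore estimated at 5 ug/mL, with a range from 2.5 ug/mL to 10 ug/mL.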

Compound 4, half-maximal inhibitory concentration: 2.8 ug/mL
Estimate against measurement, compound 4: 1.8-fold (0.25 log units) above; the measured number falls inside the stated range.
By their numbers in this assay, from the lowest: compounds 4, 2, 1 and 3 (each within the scatter of the next, the first and the last beyond it).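

Within the data shown here, on the carbonyl carbon, 4-aminophenyl in place of 3,4-dichlorophenyl gives a 2.7-fold lower number from compound 3 to compound 4 (0.43 log units; beyond the scatter) and is the first step to lower the number beyond the scatter. Amino in place of hydrogen on an aromatic carbon gives a 1.3-fold lower number from compound 2 to compound 4 (0.12 log units; within the scatter) and amino in place of butoxy gives a 1.9-fold lower number from compound 1 to compound 4 (0.28 log units; within the scatter) so compound 4 separates from compound 3 alone. Nothing at hand gives a cause for these steps.

Open, as far as these compounds go, is whether the step follows the amino group or the absence of chlorine: a 4-chlorophenyl or 4-hydroxyphenyl ring at this place would help separate the two.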